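The source may hold more compounds than are shown below. What is called first, only, known or untested is meant among the compounds shown, and "the series" means these compounds.

Working notes on the series, read in an ADME assay on L929 cells (Mus musculus) for cytotoxicity, read by resazurin assay, with a stated time of 72 h; a lower number here means a stronger inhibitor, a higher number a weaker inhibitor. Compound 1 (`O=C(/C=C/c1ccc2c(c1)B(O)OC2)c1ccccn1`) gives > 10 ug/mL, which is a limit of the assay. Compound 2 (`O=C(/C=C/c1ccc2c(c1)B(O)OC2)c1ccccc1O`) gives > 10 ug/mL, also only a limit. For the measured compounds named here, the sole measured step is a step that the two limits leave unreadable from compound 1 to compound 2, and the evidence amounts to the limit of > 10 ug/mL in this assay, at which 2 of the 2 values shown sit. Compound 3 (`COCOc1ccccc1C(=O)/C=C/c1ccc2c(c1)B(O)OC2`) carries methoxymethyl in place of hydrogen on an oxygen on an aromatic ring, methoxymethyl in place of hydrogen on an oxygen on an aromatic ring. No measured step sizes this change, so no step beyond the scatter is expected. The expected step is a step that the limit leaves unreadable from compound 2 to compound 3. The estimate for compound 3 is 20 ug/mL, within an expected range of 7 ug/mL to 60 ug/mL.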

Compound 3, half-maximal inhibitory concentration: 9.02 ug/mL
The estimate for compound 3 lay 2.2-fold (0.35 log units) above the measured number; low and high end bracket the measured number.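

In this assay, for the compounds shown here, methoxymethyl in place of hydrogen on an oxygen on an aromatic ring gives the first number that is not a limit, with an at least 1.1-fold lower number from compound 2 to compound 3 (0.04 log units; that floor lies within the scatter). This shows that a measurable cytotoxic reading is reachable with a change at this oxygen, although the step is bounded on one side only: the limit of > 10 ug/mL in this assay, at which 2 of the 3 values shown sit.

Going by these compounds, what a plain methoxy or a longer ether chain on this oxygen would give remains open. On these data alone, the true distance between compound 2 and compound 3 also remains open.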